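The compounds below may be only part of what the source reports. "The series", "measured", "known", "first", "only" and "open" are said of these compounds alone.

Measured in a functional assay (Homo sapiens) for inhibition, read by sulforhodamine B assay, with a stated time of 3 days; a higher number here means a weaker inhibitor, a lower number a stronger inhibitor:
compound 1 (`Clc1nc2c(NCc3ccccc3)nc(N3CCNCC3)nc2nc1N1CCCC1`): 4000 nM
compound 2 (`CC(=O)N1CCN(c2nc(N3CCCC3)c3nc(Cl)c(NCc4ccccc4)nc3n2)CC1`): 13000 nM

Compound 2 stands highest of the two numbers, so it is the weaker inhibitor, and compound 1 lies lower by more than the usual scatter. Compound 3 (`OCCNc1nc(N2CCCC2)c2nc(Cl)c(NCc3ccccc3)nc2n1`) has not yet been measured. The change ((2-hydroxyethyl)amino in place of 4-acetylpiperazin-1-yl on an aromatic carbon) puts (2-hydroxyethyl)amino in place of 4-acetylpiperazin-1-yl on an aromatic carbon, between two ring nitrogen atoms. Among the compounds with values here, no measured step covers this exchange, so the expectation rests only on compound 2 at 13000 nM and compound 1 at 4000 nM as a frame. A lower number than compound 2 is expected in this assay, of a size near the edge of the scatter. The estimated step is a 1.9-fold lower number from compound 2 to compound 3 (0.27 log units; within the scatter) and it remains uncertain. Compound 3 is estimated at 7000 nM, with an expected range of 2500 nM to 20000 nM.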

Compound 3, half-maximal inhibitory concentration: 15200 nM
Compound 3: middle estimate off by 2.2-fold (0.34 log units), on the low side; low and high end bracket the measured number.
By their numbers in this assay, from the lowest: compound 1; then compounds 2 and 3 (each within the scatter of the next).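

In this assay the exchange on this aromatic carbon, between two ring nitrogen atoms, gives a 1.2-fold higher number from compound 2 to compound 3 (0.07 log units; within the scatter), so the two compounds read alike. At this position, the six-membered non-aromatic ring and the acetyl carbonyl can therefore be replaced by an open chain with fewer heavy atoms and more hydrogen-bond donors, with no shift in the number beyond the scatter. No measurement on these compounds bears on why the two groups read alike.

Within the data shown here, compound 1 , at 4000 nM, remains the only compound of the three with a clearly lower number. Still open, on these data alone, is whether an amine at the end of the chain, as in (2-aminoethyl)amino, would move the number toward that of compound 1 , and whether a longer chain, such as (3-hydroxypropyl)amino, or a carboxylic acid would leave it unchanged.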